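Swapping One Aromatic Ring Group for Another

A few compounds are considered here, and "the series" means these few. Any claim that something is new, unique, unknown or untested is made for them only; others in the source may bear on it.

Values in a functional assay on KYSE-70 cells for antiproliferative activity against KYSE-70 cell line (Homo sapiens), read by MTT assay, with a stated time of 72 h; on this read-out lower numbers stand for stronger inhibition and higher numbers for weaker inhibition:
- Compound 1 `O=C(Nc1cccc(F)c1)c1cc(=O)[nH]c2cc(F)ccc12`: > 20000 nM, which is a limit and not a number
- Compound 2 `O=C(Nc1cccc(F)c1)c1cc(=O)[nH]c2cc(-c3ccsc3)ccc12`: 5100 nM
- Compound 3 `O=C(Nc1cccc(F)c1)c1cc(=O)[nH]c2cc(-c3cccc(F)c3)ccc12`: 12000 nM

Going by the values given here, compound 3 carries the higher of the two actual numbers, and its only measured neighbour is compound 2, as a 2.4-fold higher number from compound 2 to compound 3 (0.37 log units; beyond the scatter) shows. Compound 1 offers only a limit (the limit of > 20000 nM in this assay, at which 1 of the 3 values shown sits).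

Compound 4 `Cc1ccc(-c2ccc3c(C(=O)Nc4cccc(F)c4)cc(=O)[nH]c3c2)cc1` keeps the shared core and the amide, and changes one group: 4-methylphenyl in place of 3-fluorophenyl on an aromatic carbon.

Three measured steps change this same place. Replacing the fluoro of compound 1 gives an at least 3.9-fold lower number from compound 1 to compound 2 (0.59 log units; beyond the scatter) and an at least 1.6-fold lower number from compound 1 to compound 3 (0.22 log units; that floor lies within the scatter). These two show that the group here can matter, but each starts from a limit, so they fix no exact size. The closest guide is the swap of one aromatic group for another, a 2.4-fold higher number from compound 2 to compound 3 (0.37 log units; beyond the scatter), which is modest. Among the compounds with values here, the new change is milder in kind, since a six-membered carbon ring stays a six-membered carbon ring, and no measured step shows its direction.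

The estimated step is a 1.2-fold lower number from compound 3 to compound 4 (0.08 log units; within the scatter), so no shift beyond the scatter is expected. The expected value for compound 4 is 10000 nM. The estimated range for compound 4 runs from 4500 nM to 20000 nM.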

Compound 4, half-maximal inhibitory concentration: > 20000 nM
Compound 4 ended at the assay's limit (the forecaster's own chance of this, stated with the estimate: 15%); middle value at least 2.0-fold (0.30 log units) away from the limit.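

Putting 4-methylphenyl on this aromatic carbon in place of thiophen-3-yl gives an at least 3.9-fold higher number from compound 2 to compound 4 (0.59 log units; beyond the scatter), so compound 2 now stands apart from both six-membered aromatic rings tested here, and the choice of ring at this position clearly affects the read-out. The comparison with 3-fluorophenyl gives an at least 1.6-fold higher number from compound 3 to compound 4 (0.22 log units; that floor lies within the scatter), a floor within the scatter, so the data do not separate these two groups, although the true gap could be larger. The step between compound 1 and compound 4 cannot be read, since both sit at a limit rather than at a number: the limit of > 20000 nM in this assay, at which 2 of the 4 values shown sit.

From the compounds shown here alone, it remains open whether the advantage of thiophen-3-yl extends to other five-membered rings, such as furan-3-yl or thiophen-2-yl, or whether it is specific to this one group. The compounds shown also cannot tell whether the methyl group or its place on the ring matters more, a question that 3-methylphenyl and 4-fluorophenyl could help answer, and they say nothing about a ring carrying an amine or a carboxylic acid.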